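Changing the Group on the Aromatic Nitrogen

The source may hold more compounds than are shown below. What is called first, only, known or untested is meant among the compounds shown, and "the series" means these compounds.

Three compounds built on one shared core differ only in the amine at the end of a three-carbon chain. Compound 1 `COc1cc2c(Oc3ccc(NC(=O)c4nn(-c5ccccc5OC(F)(F)F)c(=O)cc4C)cc3F)ccnc2cc1OCCCN1CCCC1` gives 210 nM in a functional assay on NCI-H460 cells (Homo sapiens) for inhibition, read by MTT assay, with a stated time of 72 h; on this read-out higher numbers stand for weaker inhibition and lower numbers for stronger inhibition. Compound 2 `COc1cc2c(Oc3ccc(NC(=O)c4nn(-c5ccccc5OC(F)(F)F)c(=O)cc4C)cc3F)ccnc2cc1OCCCN1CCCCC1` gives 230 nM in this assay, and compound 3 `COc1cc2c(Oc3ccc(NC(=O)c4nn(-c5ccccc5OC(F)(F)F)c(=O)cc4C)cc3F)ccnc2cc1OCCCN1CCN(C)CC1` gives 260 nM. Compound 2 stands second highest of the three numbers, with compound 1 nearest and compound 3 furthest, yet all three values lie within the usual scatter of one another, so none can be called stronger or weaker. The steps of a 1.1-fold higher number from compound 1 to compound 2 (0.04 log units; within the scatter), a 1.2-fold higher number from compound 1 to compound 3 (0.09 log units; within the scatter) and a 1.1-fold higher number from compound 2 to compound 3 (0.05 log units; within the scatter) are all small.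

Compound 4 `COc1cc2c(Oc3ccc(NC(=O)c4nn(-c5ccc(Cl)cc5Cl)c(=O)cc4C)cc3F)ccnc2cc1OCCCN1CCCCC1` differs from compound 2 at another place: 2,4-dichlorophenyl in place of 2-(trifluoromethoxy)phenyl on an aromatic nitrogen. Among the measured compounds shown here, none of the measured steps touches this group; all three changed the amine at the chain end and all stayed within the scatter, so they say nothing about the group on the aromatic nitrogen. For the measured compounds named here, with no measured step bearing on it, the step of a 1.1-fold higher number from compound 2 to compound 4 (0.04 log units; within the scatter) is only an expectation and carries a wide range. Compound 4 is therefore estimated at 250 nM, between 70 nM and 900 nM.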

Compound 4, half-maximal inhibitory concentration: 390 nM
Compound 4: middle estimate off by 1.6-fold (0.19 log units), on the low side; the measured number falls inside the stated range.
By their numbers in this assay, from the lowest: compounds 1, 2, 3 and 4 (each within the scatter of the next).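

Among the compounds shown here, this is the first measured change at the group on the aromatic nitrogen: in this assay, 2,4-dichlorophenyl in place of 2-(trifluoromethoxy)phenyl gives a 1.7-fold higher number from compound 2 to compound 4 (0.23 log units; within the scatter). The two groups therefore cannot be told apart on this read-out, even though the entering group has fewer heavy atoms and carries chlorine rather than oxygen and fluorine. Nothing measured here offers an explanation for this result.

Still open, from the compounds shown here alone, is whether the same holds for quite different groups on this nitrogen, such as a plain phenyl, a cyclohexyl or a simple methyl. Also open, going by these compounds, is whether 2,4-dichlorophenyl gives similar numbers when the chain ends in another amine, such as pyrrolidin-1-yl or morpholin-4-yl, rather than the piperidin-1-yl of compound 4.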